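Swapping methyl for methoxyphenyl on the sulfonyl sulfur

The compounds below may be only part of what the source reports. "The series", "measured", "known", "first", "only" and "open" are said of these compounds alone.

Three sulfonamides built on one shared core have been measured in an ADME assay on HEK293 cells (Homo sapiens) for cytotoxicity, read by resazurin assay, with a stated time of 48 h; a higher number here means that more compound is tolerated, a lower number that less compound is tolerated. Compound 1 `O=S(=O)(Nc1ccc2oc(-c3ccccc3)nc2c1)c1cccs1` gives 97000 nM. Compound 2 `O=S(=O)(Nc1ccc2oc(-c3ccccc3)nc2c1)c1ccc(O)cc1` reaches a limit of the assay, > 100000 nM. Compound 3 `CS(=O)(=O)Nc1ccc2oc(-c3ccccc3)nc2c1` also stands at a limit of the assay, > 100000 nM. This is the limit of > 100000 nM in this assay, at which 2 of the 3 values shown sit, so compound 3 stands at the top of the numbers shown rather than at a measured point. The steps of an at least 1.0-fold higher number from compound 1 to compound 2 (0.01 log units; that floor lies within the scatter) and an at least 1.0-fold higher number from compound 1 to compound 3 (0.01 log units; that floor lies within the scatter) are both floors lying within the scatter, and the step that the two limits leave unreadable from compound 2 to compound 3 cannot be read between two limits. Compound 4 `COc1ccc(S(=O)(=O)Nc2ccc3oc(-c4ccccc4)nc3c2)cc1` is not yet measured; it differs from compound 3 thus: 4-methoxyphenyl in place of methyl on a sulfonyl sulfur. The change resembles that from compound 1 to compound 2, where 4-hydroxyphenyl in place of thiophen-2-yl left the number at a limit. Within the data shown here, no measured step therefore points to a step beyond the scatter, and compound 4 is expected to sit near the same limit, with a number no higher from compound 3 to compound 4 (the limit leaves the size open) as the expected step. The estimate for compound 4 in this assay is 100000 nM, between 50000 nM and 200000 nM.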

Compound 4, half-maximal cytotoxic concentration: 91000 nM
Beside the measured number, compound 4's estimate is 1.1-fold (0.04 log units) above it, and the stated range covers the measured number.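

In this assay, 4-methoxyphenyl on a sulfonyl sulfur gives a measured point rather than a limit, and its exchange for methyl comes to an at least 1.0-fold lower number from compound 3 to compound 4 (0.04 log units; that floor lies within the scatter). Methyl in place of hydrogen on an oxygen on an aromatic ring comes to an at least 1.0-fold lower number from compound 2 to compound 4 (0.04 log units; that floor lies within the scatter), and 4-methoxyphenyl in place of thiophen-2-yl comes to a 1.1-fold lower number from compound 1 to compound 4 (0.03 log units; within the scatter). None of the three steps lies beyond the scatter, and the first two are only floors, as they start from a limit: the limit of > 100000 nM in this assay, at which 2 of the 4 values shown sit.

As far as these compounds go, how far compound 2 and compound 3 lie past that limit stays open. So does whether an amine or a carboxylic acid in place of 4-methoxyphenyl on a sulfonyl sulfur would move the number beyond the scatter.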